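Trifluoromethyl variant of the anilide series: expected potency

The source may report more compounds than this note shows. Statements on the series, on what has been measured and on what is new or still open speak of the compounds shown alone.

Compound 1 `COc1ccn2c(-c3ccc(NC(=O)c4ccc([N+](=O)[O-])o4)c(C)c3)cnc2c1` and compound 2 `COc1ccn2c(-c3ccc(NC(=O)c4ccc([N+](=O)[O-])o4)c(OC)c3)cnc2c1` share one core and differ only at one aromatic carbon. In a functional assay on MGC-803 cells (Homo sapiens) for antiproliferative activity, read by CCK-8 assay, with a stated time of 72 h (a lower number here means a stronger inhibitor, a higher number a weaker inhibitor), compound 1 gives 1380 nM, while compound 2 gives 7520 nM, the higher of the two numbers; the step of a 5.4-fold higher number from compound 1 to compound 2 (0.74 log units; beyond the scatter). Compound 3 `COc1ccn2c(-c3ccc(NC(=O)c4ccc([N+](=O)[O-])o4)c(C(F)(F)F)c3)cnc2c1` carries trifluoromethyl in place of methoxy on an aromatic carbon. For the measured compounds named here, no measured step involves a trifluoromethyl group, so the single step from compound 1 to methoxy is the only guide, and it does not say whether compound 3 will resemble compound 1 or compound 2. The number for compound 3 is expected to fall between those two, a 2.1-fold lower number from compound 2 to compound 3 (0.33 log units; beyond the scatter), estimated at 3500 nM with a range from 900 nM to 14000 nM.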

Compound 3, half-maximal inhibitory concentration: 2910 nM
For compound 3 the middle estimate is 1.2-fold (0.08 log units) above the measured one; low and high end bracket the measured number.
By their numbers in this assay, from the lowest: compound 1; then compound 3; then compound 2.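

In this assay trifluoromethyl on this aromatic carbon is separated from both earlier groups, with a 2.6-fold lower number from compound 2 to compound 3 (0.41 log units; beyond the scatter) and a 2.1-fold higher number from compound 1 to compound 3 (0.32 log units; beyond the scatter) as the two steps. The position therefore distinguishes three groups, with methyl giving the lowest number and methoxy the highest. No evidence is available to account for this order. From the compounds shown here alone, whether an amine, a chlorine atom or a longer chain on this carbon would give a number lower than that of compound 1 remains open. Going by these compounds, whether the same order holds in other cell lines also remains open.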